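Sulfonyl aryl variation in the series: note on compound 4

The source may hold more compounds than are shown below. What is called first, only, known or untested is meant among the compounds shown, and "the series" means these compounds.

Three compounds have been measured in an ADME assay on microsomes from liver (Homo sapiens) for metabolic stability, tested at 2.5 uM; a higher number here means faster removal of the compound, a lower number slower removal:

compound 1 `O=S(=O)(c1ccc(F)cc1)c1cnc2cc(F)ccc2c1-c1cccc(F)c1`: 0.95 mL/min
compound 2 `COc1ccc(-c2c(S(=O)(=O)c3ccc(F)cc3)cnc3cc(F)ccc23)cc1`: 1.77 mL/min
compound 3 `O=S(=O)(c1ccc(F)cc1)c1cnc2cc(F)ccc2c1-c1ccc(F)cc1`: 1.34 mL/min

Compound 1 sits at the low end of these three numbers, but the spread is small: the nearest value is that of compound 3, a 1.4-fold higher number from compound 1 to compound 3 (0.15 log units; within the scatter), and the furthest that of compound 2, a 1.9-fold higher number from compound 1 to compound 2 (0.27 log units; within the scatter). Between compound 2 and compound 3 the step is a 1.3-fold lower number from compound 2 to compound 3 (0.12 log units; within the scatter). All three steps lie within the scatter, so the three compounds are not separated in this assay.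

The next compound is compound 4 `Cc1ccc(S(=O)(=O)c2cnc3cc(F)ccc3c2-c2cccc(F)c2)cc1F`. Relative to compound 1 the change is 3-fluoro-4-methylphenyl in place of 4-fluorophenyl on a sulfonyl sulfur. For the measured compounds named here, every measured step so far alters the aryl group on the aromatic carbon of the shared core, and the group on the sulfonyl sulfur has been 4-fluorophenyl throughout. Going by the values given here, no measured step therefore bears directly on this change. What the series does show is that each aryl change tried so far gave a step within the scatter in this assay. On that basis compound 4 is expected to stay close to compound 1, with a step of a 1.3-fold higher number from compound 1 to compound 4 (0.10 log units; within the scatter) and no change beyond the scatter. The estimate for compound 4 in this assay is 1.2 mL/min, expected within the range 0.55 mL/min to 2.6 mL/min.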

Compound 4, intrinsic clearance in a liver preparation (reported as CLH), per the amount of preparation that the assay uses: 0.41 mL/min
For compound 4 the middle estimate is 2.9-fold (0.47 log units) above the measured one; the measured number lies below the stated range.
By their numbers in this assay, from the lowest: compound 4; then compounds 1, 3 and 2 (each within the scatter of the next).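

The group on the sulfonyl sulfur is the only place among the compounds shown where a one-place change carries this assay beyond the scatter: 3-fluoro-4-methylphenyl in place of 4-fluorophenyl gives a 2.3-fold lower number from compound 1 to compound 4 (0.36 log units; beyond the scatter), a modest step. Compound 4 therefore stands apart at the low end, whereas compounds 1, 2 and 3, which all keep 4-fluorophenyl on the sulfonyl sulfur and vary only the aryl group on the aromatic carbon of the shared core, remain unseparated. Nothing available explains this step.

Open is whether the step belongs to the methyl, to the fluoro in its new place on the ring, or to the two together, as the compounds shown include neither 4-methylphenyl nor 3-fluorophenyl alone on the sulfonyl sulfur. Also open, from the compounds shown here alone, are whether the same exchange gives a similar step with the 4-methoxyphenyl or 4-fluorophenyl group of compounds 2 and 3 on the aromatic carbon, and how a non-aromatic group on the sulfonyl sulfur, such as a cyclohexyl ring or a longer alkyl chain, or an amine on the aryl ring there, would read in this assay.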